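A new group on the sulfonyl sulfur of compound 3

This account rests on a few compounds, and the source may have more. Where it says the series, first, only, none or still open, it means among the compounds named here.

Values from an ADME assay on the whole organism (Rattus norvegicus, strain Sprague-Dawley) for pharmacokinetics, read by LC-MS, with a stated time of 30 min (a higher number here means that more of the compound sits outside the plasma, a lower number that more of the compound stays in the plasma), for the measured compounds:
- Compound 1 `N#Cc1ccc(O[C@H]2CN(S(=O)(=O)c3ccc(Cl)cc3Cl)C[C@]2(O)CO)cc1F` gives 330 L/kg
- Compound 2 `N#Cc1ccc(O[C@H]2CN(S(=O)(=O)c3ccc(C(F)(F)F)cc3C#N)C[C@@]2(O)CO)cc1F` gives 73 L/kg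
- Compound 3 `N#Cc1ccc(O[C@H]2CN(S(=O)(=O)c3ccccc3C#N)C[C@@]2(O)CO)cc1F` gives 4.6 L/kg

Compound 3 stands lowest of these three (4.6 L/kg). Compound 4 `N#Cc1ccc(O[C@H]2CN(S(=O)(=O)c3ccc(C(F)(F)F)nc3)C[C@@]2(O)CO)cc1F` differs from it by 6-(trifluoromethyl)pyridin-3-yl in place of 2-cyanophenyl on a sulfonyl sulfur in one place: 6-(trifluoromethyl)pyridin-3-yl in place of 2-cyanophenyl on a sulfonyl sulfur. Among the compounds with values here, one measured step bears on this, hydrogen in place of trifluoromethyl (a 16-fold lower number from compound 2 to compound 3 (1.20 log units; beyond the scatter)), which is large. Within the data shown here, compound 4 carries trifluoromethyl again, but it has no nitrile and its ring holds a hetero atom, and no measured step covers those changes. So only part of that rise is expected to return, and the expected step is upward (a 4.3-fold higher number from compound 3 to compound 4 (0.64 log units; beyond the scatter)). For compound 4 the estimated value is 20 L/kg (expected range 6 L/kg to 70 L/kg).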

Compound 4, volume of distribution at steady state: 28 L/kg
Compound 4: middle estimate off by 1.4-fold (0.15 log units), on the low side, and the stated range covers the measured number.
By their numbers in this assay, from the lowest: compound 3; then compound 4; then compound 2; then compound 1.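

In this assay the new group on the sulfonyl sulfur gives a 6.1-fold higher number from compound 3 to compound 4 (0.78 log units; beyond the scatter) and so shows that the number can climb at this position with no nitrile on the group at all. The earlier step changed only trifluoromethyl on a ring that kept its nitrile. Here the nitrile, the ring hetero atom and trifluoromethyl all change at once, so their separate shares cannot be told apart. Going by these compounds, whether an amine or a carboxylic acid on this ring would bring the number down again stays open. Nothing measured here explains the rise.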